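The source may hold more compounds than are shown below. What is called first, only, known or untested is meant among the compounds shown, and "the series" means these compounds.

Compound 1 `CCN(c1nc(C)cc(C)n1)c1ccc(OC)cc1Br` gives 35 nM in an assay on isolated protein for binding affinity to corticotropin-releasing factor receptor 1 (Homo sapiens); a lower number here means a stronger inhibitor, a higher number a weaker inhibitor. Going by the values given here, compound 2 `CCN(c1nc(C)cc(C)n1)c1c(Br)cc(OC)cc1OC` carries one more methoxy on an aromatic carbon, and in this assay compound 2 gives 12 nM, the lowest of the two numbers so far; the only measured step, a 2.9-fold lower number from compound 1 to compound 2 (0.46 log units; beyond the scatter), is modest and beyond the scatter. Compound 3 `CCN(c1nc(C)cc(C)n1)c1c(Br)cc(N(C)C)cc1OC` differs from compound 2 by dimethylamino in place of methoxy on an aromatic carbon. Among the compounds with values here, no measured step bears directly on this exchange: the measured step adds a methoxy in place of hydrogen, whereas here a methoxy is swapped for a dimethylamino, and the two measured compounds show nothing about how such a swap behaves. The expectation therefore rests on compound 2 alone, with a small step in either direction, likely within the scatter. Compound 3 is estimated at 15 nM, with a range from 5 nM to 45 nM, which corresponds to an expected step of a 1.3-fold higher number from compound 2 to compound 3 (0.10 log units; within the scatter).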

Compound 3, inhibition constant: 5 nM
Compound 3: the middle estimate sits 3.0-fold (0.48 log units) above what was measured; low and high end bracket the measured number.
By their numbers in this assay, from the lowest: compound 3; then compound 2; then compound 1.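

Dimethylamino in place of methoxy on the aromatic carbon para to a large group gives a 2.4-fold lower number from compound 2 to compound 3 (0.38 log units; beyond the scatter) in this assay, a modest step. Going by these compounds alone, this is the first measured change at this carbon, since the earlier step concerned a methoxy replacing hydrogen elsewhere on the ring, and it shows that the number here depends on the group at this position and that three heavy atoms in place of two bring no loss. No available data explain why the number falls with this exchange.

Whether the step is particular to dimethylamino stays open, as the compounds shown say nothing about a primary amine, a diethylamino group or a hydroxyl on this carbon. Also open, as far as these compounds go, is whether the same exchange would give a similar step on the core of compound 1, which lacks the second methoxy.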